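From 4-Fluorophenyl to Phenyl in a Small Series

This account rests on a few compounds, and the source may have more. Where it says the series, first, only, none or still open, it means among the compounds named here.

Three compounds that share one core and differ at a single aromatic carbon have been measured in a functional assay on A549 cells (Homo sapiens) for inhibition, read by MTT assay, with a stated time of 72 h; on this read-out lower numbers stand for stronger inhibition and higher numbers for weaker inhibition. Compound 1 `Cc1ccc(-c2nnc(SCCCN3CCN(c4nc5ccccc5s4)CC3)o2)cc1`, which carries methyl there, gives 53900 nM. Compound 2 `Clc1ccc(-c2nnc(SCCCN3CCN(c4nc5ccccc5s4)CC3)o2)cc1`, which carries chloro, gives 110000 nM. Compound 3 `Fc1ccc(-c2nnc(SCCCN3CCN(c4nc5ccccc5s4)CC3)o2)cc1`, which carries fluoro, gives 71700 nM, within the scatter of both other values.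

Compound 4 `c1ccc(-c2nnc(SCCCN3CCN(c4nc5ccccc5s4)CC3)o2)cc1` differs from compound 3 by hydrogen in place of fluoro on an aromatic carbon, para to a large group. This exact exchange has not been measured, so the closest guide is the other exchanges on that carbon. Fluoro in place of methyl gave a 1.3-fold higher number from compound 1 to compound 3 (0.12 log units; within the scatter), and fluoro in place of chloro gave a 1.5-fold lower number from compound 2 to compound 3 (0.19 log units; within the scatter). Chloro in place of methyl gave a 2.0-fold higher number from compound 1 to compound 2 (0.31 log units; beyond the scatter), the only modest step beyond the scatter. No step beyond the scatter is therefore expected in this assay, in either direction. The expected change is a 1.0-fold lower number from compound 3 to compound 4 (0.01 log units; within the scatter). For compound 4 the estimated value is 70000 nM, with an expected range from 35000 nM to 140000 nM.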

Compound 4, half-maximal inhibitory concentration: 257000 nM
Compound 4: middle estimate off by 3.7-fold (0.56 log units), on the low side, and the stated range ends below it.
By their numbers in this assay, from the lowest: compounds 1, 3 and 2 (each within the scatter of the next, the first and the last beyond it); then compound 4.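

In this assay, for the compounds shown here, this position behaves differently from what the earlier compounds suggested: exchanges among methyl, fluoro and chloro moved the number little, but hydrogen on this carbon stands apart from all three. The loss appears against each of them, as (a 3.6-fold higher number from compound 3 to compound 4 (0.55 log units; beyond the scatter)), (a 2.3-fold higher number from compound 2 to compound 4 (0.37 log units; beyond the scatter)) and (a 4.8-fold higher number from compound 1 to compound 4 (0.68 log units; beyond the scatter)), so compound 4 is the weakest of the four, with every step beyond the scatter. Among these compounds, then, having any of the three groups para to a large group goes with a lower number than having none, and no compound shown goes against this.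

As far as these compounds go, it remains open whether a methoxy group, a nitrile, an amine or a carboxylic acid on this carbon would also give a lower number than hydrogen. Nothing available here explains why hydrogen differs from the other three groups.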